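Hydrogen for chloro: a step from an inactive compound

The compounds below may be only part of what the source reports. "The series", "measured", "known", "first", "only" and "open" are said of these compounds alone.

Measured so far:
compound 1 `Cc1ccc(C2CNN=C2S(=O)(=O)CC2=NCCS2)cc1`: 42.2%
compound 2 `O=S(=O)(CC1=NCCS1)C1=NNCC1c1ccc(Cl)cc1`: "not active" (no number reported)

In a functional assay, tested at 75 ug/mL (on this read-out higher numbers stand for a stronger effect at the one concentration tested and lower numbers for a weaker effect), compound 1 gives 42.2%. For the measured compounds named here, compound 2 is reported in this assay only as "not active" (no number reported), so no single number fixes where it stands, and no measured step can be drawn from it. Compound 3 `O=S(=O)(CC1=NCCS1)C1=NNCC1c1ccccc1` is compound 2 with one change: hydrogen in place of chloro on an aromatic carbon. With no number for compound 2, the size of this step cannot be known; a modest gain in this assay is possible, yet another report of no activity is about as likely. Compound 3 is expected to give roughly 20%, within 0% to 50%.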

Compound 3, a percentage reported as activity, at one concentration (the size of the read-out at that concentration, not a potency): "not active" (no number reported)
Compound 3 has no reported number here, so the estimate cannot be set against anything.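

Compound 2 and compound 3 are both reported only as not active in this assay, so no step can be read between them. No measured evidence bears on this result. The compounds shown leave open whether the change from 4-chlorophenyl to phenyl has any effect at all.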